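The compounds below may be only part of what the source reports. "The series", "measured", "known", "first", "only" and "open" are said of these compounds alone.

Of the compounds shown here, three of a shared core have been measured in an assay on membranes from HeLa cells for displacement of a labelled ligand from adenosine receptor A3 (Homo sapiens), read by scintillation counting, with a stated time of 180 min, tested at 1 uM; a lower number here means less inhibition, a higher number more inhibition at the concentration tested (going by the name of the read-out). Compound 1, `CC1=C(C(=O)OCC(C)C)C(c2cccs2)NC(=O)N1`, gives 11% in this assay. Compound 2, `COC(=O)C1=C(C)N(C)C(=O)NC1c1cccs1`, gives 15%. Compound 3, `CC1=C(C(=O)OC(C)C)C(c2cccs2)NC(=O)N1C`, gives 17%, and its number is the highest of the three, although it sits within the usual scatter of both compound 2 and compound 1. For the measured compounds named here, the only single-point step among them is the change a number 2 percentage points higher from compound 2 to compound 3 (within the scatter), an isopropyl in place of a methyl on an oxygen next to a carbonyl group, and it stays within the scatter.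

Compound 4, `CC1=C(C(=O)OCC(C)C)C(c2cccs2)NC(=O)N1C`, is compound 3 with one change: isobutyl in place of isopropyl on an oxygen next to a carbonyl group. This is the same kind of alteration as the step from compound 2 to compound 3, the alkyl on the oxygen next to the carbonyl group growing by a carbon, and that step was within the scatter. Compound 1, which also carries an isobutyl at this place but differs from compound 3 in a second position as well, gives a number in the same low region. Compound 4 is therefore expected to show no step beyond the scatter, a number 1 percentage points lower from compound 3 to compound 4 (within the scatter), in this assay. The estimate for compound 4 is 16%, within a range from 7% to 26%.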

Compound 4, a percentage reported as inhibition, at one concentration (the size of the read-out at that concentration, not a potency): 5%
Compound 4: the middle estimate sits 11 percentage points above what was measured, outside the stated range (below it).
By their numbers in this assay, from the lowest: compounds 4, 1, 2 and 3 (each within the scatter of the next, the first and the last beyond it).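

In this assay, a number 12 percentage points lower from compound 3 to compound 4 (beyond the scatter) with isobutyl in place of isopropyl on an oxygen next to a carbonyl group, and this is a step beyond the scatter, whereas a number 2 percentage points higher from compound 2 to compound 3 (within the scatter) at the same place did not leave it. Growth of the alkyl group at this place therefore does not act evenly across the compounds shown, although the change is modest and compound 4 at 5% and compound 3 at 17% both lie low in the range of the read-out. The two other new steps stay within the scatter: a number 10 percentage points lower from compound 2 to compound 4 (within the scatter) with isopropyl in place of hydrogen on a saturated chain carbon bound to an oxygen next to a carbonyl group, and a number 6 percentage points lower from compound 1 to compound 4 (within the scatter) with methyl in place of hydrogen on an amide-type nitrogen in a ring, and nothing at hand bears on why the isobutyl step differs.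

On these data alone, whether a longer chain such as hexyl, or a benzyl group, on this oxygen would carry the number further down or bring it back up remains open. A single concentration also gives no potency, so how far these compounds truly differ at the receptor stays unsettled.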